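Adding Trifluoromethyl to a Fluoro-Bearing Analogue of Compound 2

This account rests on a few compounds, and the source may have more. Where it says the series, first, only, none or still open, it means among the compounds named here.

Compound 1 `CC1=C(/C=C/C(=O)/C=C/c2ccccc2C(F)(F)F)C(C)(C)CCC1O` gives 2300 nM in a functional assay on CWR22R cells (Homo sapiens) for cytotoxicity, read by MTT assay, with a stated time of 72 h; on this read-out lower numbers stand for stronger inhibition and higher numbers for weaker inhibition.
Compound 2 `CC1=C(/C=C/C(=O)/C=C/c2ccccc2F)C(C)(C)CCC1O` gives 3300 nM in this assay.
Compound 3 `CC1=C(/C=C/C(=O)/C=C/c2cccc(C(F)(F)F)c2F)C(C)(C)CCC1O` has "not determined" (no result reported) in this assay, so no result is reported for it.

Among the measured compounds shown here, only two numbers are known, so compound 2 can be placed only against compound 1: the step of a 1.4-fold higher number from compound 1 to compound 2 (0.16 log units; within the scatter) lies within the scatter, and the two compounds are not separated by this read-out. Compound 4 `CC1=C(/C=C/C(=O)/C=C/c2c(F)cccc2C(F)(F)F)C(C)(C)CCC1O` keeps the fluoro group of compound 2 and differs from it by trifluoromethyl in place of hydrogen on an aromatic carbon. For the measured compounds named here, the one measured step that bears on this change is the exchange of trifluoromethyl for fluoro between compound 1 and compound 2, which was a 1.4-fold higher number from compound 1 to compound 2 (0.16 log units; within the scatter) and within the scatter. Since neither group alone set the two compounds apart, carrying both groups on the same ring is expected to leave the number near that of compound 2 and no step beyond the scatter is expected in this assay. The expected step for compound 4 is therefore a 1.3-fold lower number from compound 2 to compound 4 (0.10 log units; within the scatter). Compound 4 is estimated at 2600 nM in this assay, with a likely range from 1200 nM to 5500 nM.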

Compound 4, half-maximal inhibitory concentration: 8900 nM
Estimate against measurement, compound 4: 3.4-fold (0.53 log units) below; the measured number lies above the stated range.
By their numbers in this assay, from the lowest: compounds 1 and 2 (each within the scatter of the next); then compound 4.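

Putting a group on this aromatic carbon, ortho to a large group and meta to a fluoro group, does move the result in this assay when trifluoromethyl replaces hydrogen (a 2.7-fold higher number from compound 2 to compound 4 (0.43 log units; beyond the scatter)). Adding fluoro in place of hydrogen to compound 1 gives a step of similar, modest size in the same direction (a 3.9-fold higher number from compound 1 to compound 4 (0.59 log units; beyond the scatter)). The earlier exchange of one group for the other did not separate two compounds, whereas here, carrying both groups on the ring goes with weaker inhibition than carrying either one alone. Nothing shown here explains this rise.

Compound 3 carries the same two groups in another arrangement but has no number, so its steps cannot be read. Going by these compounds, whether an amine or a carboxylic acid on this carbon would shift the number in the same way remains open.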